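Fluorine on the Amide Aryl in a Cytotoxicity Series

The source may hold more compounds than are shown below. What is called first, only, known or untested is meant among the compounds shown, and "the series" means these compounds.

Compound 1 `O=C(NC1CCCCC1)c1c(NO)cc(-c2ccccc2)oc1=O`: 10500 nM
Compound 2 `O=C(NC1CCCCC1)c1c(NO)cc(-c2ccc(F)cc2)oc1=O`: 11400 nM
Compound 3 `O=C(Nc1ccccc1)c1c(NCCO)cc(-c2cccc(Br)c2)oc1=O`: > 20000 nM, which is a limit of the assay rather than a number

All three were tested in an ADME assay on Huh-7 cells (Homo sapiens) for cytotoxicity, with a stated time of 3 days; a lower number here means that less compound is tolerated, a higher number that more compound is tolerated. Compound 1 and compound 2 differ by fluoro in place of hydrogen on an aromatic carbon, and the step is a 1.1-fold higher number from compound 1 to compound 2 (0.04 log units; within the scatter). Compound 3 reaches (the limit of > 20000 nM in this assay, at which 1 of the 3 values shown sits). How the core of compound 3 differs from the core of compound 1 is not broken down here.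

Compound 4 `O=C(Nc1ccc(F)cc1)c1c(NCCO)cc(-c2cccc(Br)c2)oc1=O` has not yet been tested. Within the data shown here, it differs from compound 3 by fluoro in place of hydrogen on an aromatic carbon, the same change as the one from compound 1 to compound 2, since the two place descriptions agree word for word. In this assay the step from compound 3 to compound 4 is expected to be small, a number no higher from compound 3 to compound 4 (the limit leaves the size open), because a 1.1-fold higher number from compound 1 to compound 2 (0.04 log units; within the scatter) was within the scatter. Compound 4 is therefore expected to sit near 20000 nM, most likely again reported only as a limit, with a range of 10000 nM to 40000 nM.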

Compound 4, half-maximal cytotoxic concentration: > 20000 nM
Compound 4: a limit, no number; the forecaster's own chance of this, stated with the estimate: 65%; the middle value lies on the limit itself.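

No step can be read from compound 3 to compound 4 in this assay, because each is reported only as a limit of the assay, not as a number: the limit of > 20000 nM in this assay, at which 2 of the 4 values shown sit.

The compounds shown leave open what concentration of compound 3 or compound 4 is actually tolerated, and whether phenyl to 4-fluorophenyl on the amide changes it at all.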